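Varying the group on a sulfonamide nitrogen

A few compounds are considered here, and "the series" means these few. Any claim that something is new, unique, unknown or untested is made for them only; others in the source may bear on it.

Measured compounds in a functional assay on HepG2 cells (Homo sapiens) for antiproliferative activity, read by sulforhodamine B assay, with a stated time of 48 h; a lower number here means a stronger inhibitor, a higher number a weaker inhibitor:
compound 1 `CC(=O)NS(=O)(=O)c1ccc(N/C(S)=N\c2ccnc3cc(C(F)(F)F)ccc23)cc1` gives 28400 nM
compound 2 `Cc1cc(NS(=O)(=O)c2ccc(N/C(S)=N\c3ccnc4cc(C(F)(F)F)ccc34)cc2)on1` gives 28500 nM
compound 3 `O=S(=O)(Nc1nccs1)c1ccc(N/C(S)=N\c2ccnc3cc(C(F)(F)F)ccc23)cc1` gives 28200 nM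

The three compounds share one core and differ only in the group on the sulfonamide nitrogen. Compound 3 has the lowest of the three numbers in this assay, yet both of its neighbours lie within the scatter: a 1.0-fold lower number from compound 1 to compound 3 (0.00 log units; within the scatter) and a 1.0-fold lower number from compound 2 to compound 3 (0.00 log units; within the scatter). Likewise a 1.0-fold higher number from compound 1 to compound 2 (0.00 log units; within the scatter). So acetyl, 3-methyl-1,2-oxazol-5-yl and 1,3-thiazol-2-yl at this position all give the same reading.

Compound 4 `Cc1ccnc(NS(=O)(=O)c2ccc(N/C(S)=N\c3ccnc4cc(C(F)(F)F)ccc34)cc2)n1` carries the next variation at the same place: 4-methylpyrimidin-2-yl in place of 1,3-thiazol-2-yl on a sulfonamide nitrogen. All three measured steps bear on it, since each exchanged the group on this nitrogen, and none moved the number beyond the scatter. Nothing in the shown data suggests that a six-membered ring with two nitrogens would behave differently here. The step from compound 3 to compound 4 in this assay is therefore expected to be a 1.0-fold lower number from compound 3 to compound 4 (0.00 log units; within the scatter), that is, no change beyond the scatter. Compound 4 is estimated at 28000 nM, with a range from 14000 nM to 56000 nM.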

Compound 4, half-maximal inhibitory concentration: "not active" (no number reported)
No number was reported for compound 4; no gap can be computed for the estimate.
By their numbers in this assay, from the lowest: compounds 3, 1 and 2 (each within the scatter of the next).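

In this assay, among these compounds, compound 4 is reported only as "not active", without a number, so no step from compound 3 to compound 4 can be read. The compounds shown leave open how far compound 4 lies from compound 3 in this assay. Nothing shown offers an explanation for this result.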